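Dropping a Methoxy Group: Expected Effect on Growth Inhibition

The compounds below may be only part of what the source reports. "The series", "measured", "known", "first", "only" and "open" are said of these compounds alone.

Of the compounds shown here, three sharing one core have been measured in a functional assay on PC-3 cells (Homo sapiens) for inhibition, read by sulforhodamine B assay, with a stated time of 48 h; on this read-out lower numbers stand for stronger inhibition of growth and higher numbers for weaker inhibition of growth. Compound 1 `CC(=O)/C(=C\c1c(-c2ccccc2)[nH]c2ccccc12)S(=O)(=O)c1ccccc1` gives 2500 nM. Compound 2 `O=C(/C(=C\c1c(-c2ccccc2)[nH]c2ccccc12)S(=O)(=O)c1ccccc1)c1ccccc1`, which carries a phenyl in place of methyl on a carbonyl carbon, gives 5000 nM; the step of a 2.0-fold higher number from compound 1 to compound 2 (0.30 log units; within the scatter) is within the scatter. Compound 3 `COc1ccc2[nH]c(-c3ccccc3)c(/C=C(\C#N)S(=O)(=O)c3ccccc3)c2c1`, which carries a nitrile and a methoxy group, gives 8300 nM, the highest of the three numbers; its gap to compound 2 is within the scatter, and only its gap to compound 1 lies beyond it.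

Compound 4 `N#C/C(=C\c1c(-c2ccccc2)[nH]c2ccccc12)S(=O)(=O)c1ccccc1` has not yet been measured. It differs from compound 3 by hydrogen in place of methoxy on an aromatic carbon. Within the data shown here, none of the measured steps concerns this change: the single measured step alters the group on the carbonyl carbon, and compounds 1 and 2 differ from compound 4 in more than one place. Among the measured compounds shown here, with no measured step bearing on removal of the methoxy group, the expectation for compound 4 is a step within the scatter, in no particular direction. In this assay compound 4 is therefore expected to give 6000 nM, with a range from 2000 nM to 20000 nM. That expectation amounts to an estimated 1.4-fold lower number from compound 3 to compound 4 (0.14 log units; within the scatter).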

Compound 4, concentration for 50% growth inhibition: 3400 nM
The estimate for compound 4 lay 1.8-fold (0.25 log units) above the measured number; measured number inside the range.
By their numbers in this assay, from the lowest: compounds 1, 4, 2 and 3 (each within the scatter of the next, the first and the last beyond it).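

Among these compounds, replacing methoxy with hydrogen on this aromatic carbon, part of the fused system of the shared core, gives in this assay a 2.4-fold lower number from compound 3 to compound 4 (0.39 log units; beyond the scatter) as a modest step, and this is the only measured change at this position. Without the methoxy group, the nitrile compound cannot be told apart from the two carbonyl compounds: cyano in place of benzoyl gives a 1.5-fold lower number from compound 2 to compound 4 (0.17 log units; within the scatter) and cyano in place of acetyl gives a 1.4-fold higher number from compound 1 to compound 4 (0.13 log units; within the scatter), and both steps lie within the scatter. Nothing measured here explains the methoxy step or connects it to any property of the group.

The compounds shown leave open how a hydroxyl group, a chlorine atom or the longer ethoxy chain would compare with methoxy and hydrogen on this aromatic carbon. They also leave open whether adding methoxy to the acetyl or benzoyl compounds would produce a step of similar size and direction, since that step has been read with the nitrile alone.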